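The compounds below may be only part of what the source reports. "The series", "measured", "known", "first", "only" and "open" are said of these compounds alone.

Within the data shown here, compound 3 `COc1ccc(CCc2nc(N)c3nn(-c4ccccc4)cc3n2)cc1` gives 380 nM in an assay on CHO cells for displacement of a labelled ligand from adenosine receptor A1 (Homo sapiens), read by scintillation counting (a higher number here means a weaker inhibitor, a lower number a stronger inhibitor), and stands second highest of the three numbers measured so far. Compound 2 `Nc1nc(/C=C/c2ccccc2)nc2cn(-c3ccccc3)nc12` gives 480 nM, which lies within the scatter of compound 3, so no order between these two can be claimed. Compound 1 `Nc1nc(Cc2ccccc2Cl)nc2cn(-c3ccccc3)nc12` gives 155 nM, a lower number whose gap to compound 3 lies beyond the scatter. Among the measured compounds shown here, the one single-point step measured so far is a 3.1-fold higher number from compound 1 to compound 2 (0.49 log units; beyond the scatter), an exchange of the group sitting on an aromatic carbon of the shared core.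

Compound 4 `COc1cccc(CCCc2nc(N)c3nn(-c4ccccc4)cc3n2)c1` differs from compound 3 at a different place: 3-methoxybenzyl in place of 4-methoxyphenyl on a saturated chain carbon, two bonds along the chain from an aromatic carbon. For the measured compounds named here, the step from compound 1 to compound 2 bears on this only loosely, as it alters the group on the aromatic carbon itself rather than the group on the saturated chain carbon exchanged here, and no measured pair mirrors the present change. It does show that variation in this region moves the number in this assay by a modest amount. Compound 4 is therefore expected to land close to compound 3, with a 1.1-fold higher number from compound 3 to compound 4 (0.02 log units; within the scatter) expected to remain within the scatter. Compound 4 is estimated at 400 nM in this assay, with a range from 150 nM to 1200 nM.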

Compound 4, inhibition constant: 0.15 nM
Compound 4: the middle estimate sits 2700-fold (3.43 log units) above what was measured, outside the stated range (below it).
By their numbers in this assay, from the lowest: compound 4; then compound 1; then compounds 3 and 2 (each within the scatter of the next).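

The exchange gives a 2500-fold lower number from compound 3 to compound 4 (3.40 log units; beyond the scatter) in this assay and so shows that this place on the saturated chain can move the number far more than a 3.1-fold higher number from compound 1 to compound 2 (0.49 log units; beyond the scatter) on the aromatic carbon had suggested. The change looks small in the computed counts, with 3-methoxybenzyl at 9 heavy atoms replacing 4-methoxyphenyl at 8, the same kind of aromatic ring on both sides, the same hydrogen-bond counts and no net charge, so a step of this size does not depend on any large difference in those counts. Nothing available here bears on why the step is so large.

The exchange alters two things at once, the methoxy group's place on the ring and the extra carbon of the benzyl group, and the compounds shown do not separate them: a 4-methoxybenzyl or a 3-methoxyphenyl group in the same place would do so. Also open, going by these compounds, is whether the low number survives a longer chain or a hydroxy group or a fluorine in place of the methoxy group.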